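This account rests on a few compounds, and the source may have more. Where it says the series, first, only, none or still open, it means among the compounds named here.

Measured so far in an ADME assay on the whole organism (Rattus norvegicus, strain Sprague-Dawley) for pharmacokinetics, read by LC-MS, at a dose of 5 mg/kg by the oral route; on this read-out lower numbers stand for lower exposure and higher numbers for higher exposure at the dose given:

- compound 1 `Cc1cccc(Cl)c1CN1CCc2cc(-c3c(C)nc(C)c([C@H](OC(C)(C)C)C(=O)O)c3N3CCC(C)(C)CC3)ccc2C1` gives 9210 ng.h/mL
- compound 2 `Cc1cccc(F)c1CN1CCc2cc(-c3c(C)nc(C)c([C@H](OC(C)(C)C)C(=O)O)c3N3CCC(C)(C)CC3)ccc2C1` gives 9630 ng.h/mL
- compound 3 `Cc1nc(C)c([C@H](OC(C)(C)C)C(=O)O)c(N2CCC(C)(C)CC2)c1-c1ccc2c(c1)CCN(Cc1ccc(F)cc1F)C2` gives 4420 ng.h/mL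

Of these three, compound 3 has the lowest number, 4420 ng.h/mL. Compound 4 `Cc1nc(C)c([C@H](OC(C)(C)C)C(=O)O)c(N2CCC(C)(C)CC2)c1-c1ccc2c(c1)CCN(c1ncnc3c1cnn3C)C2` is not yet measured and differs from compound 3 on an amine nitrogen in a ring: a group of 10 heavy atoms (6 carbon, 4 nitrogen; one five-membered aromatic ring with 2 hetero atoms, one six-membered aromatic ring with 2 hetero atoms) in place of a group of 9 heavy atoms (7 carbon, 2 fluorine; one six-membered aromatic ring of carbon only), on an amine nitrogen in a ring. The measured steps changed only the aromatic group held on a saturated chain carbon bound to that nitrogen. These steps are a 1.0-fold higher number from compound 1 to compound 2 (0.02 log units; within the scatter), a 2.1-fold lower number from compound 1 to compound 3 (0.32 log units; beyond the scatter) and a 2.2-fold lower number from compound 2 to compound 3 (0.34 log units; beyond the scatter). Within the data shown here, the last two were modest, but no measured compound carries a group like the entering one, so the guidance is weak. A modest fall is expected, estimated as a 1.5-fold lower number from compound 3 to compound 4 (0.17 log units; within the scatter). For compound 4 the estimate is 3000 ng.h/mL, with an expected range from 800 ng.h/mL to 10000 ng.h/mL.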

Compound 4, area under the concentration-time curve: 22100 ng.h/mL
The estimate for compound 4 lay 7.4-fold (0.87 log units) below the measured number, outside the stated range (above it).
By their numbers in this assay, from the lowest: compound 3; then compounds 1 and 2 (each within the scatter of the next); then compound 4.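

In this assay, the group on the amine nitrogen in a ring need not be a benzyl group: the entering two-ring group, bound directly to that nitrogen, gives a 5.0-fold higher number from compound 3 to compound 4 (0.70 log units; beyond the scatter), a 2.3-fold higher number from compound 2 to compound 4 (0.36 log units; beyond the scatter) and a 2.4-fold higher number from compound 1 to compound 4 (0.38 log units; beyond the scatter). Exposure can therefore rise past the level of all three benzyl compounds through this one position. Nothing measured here explains the rise.

Going by these compounds, the loss of the saturated chain carbon and the arrival of the ring nitrogens came together in one change, so their shares stay open. A plain phenyl group on that nitrogen would help separate them.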